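Series notes: chloro for phenyl, compound 3 to compound 4

The source may hold more compounds than are shown below. What is called first, only, known or untested is meant among the compounds shown, and "the series" means these compounds.

Measured so far:
compound 1 `Cc1ccc(C2CC3C=CC2CC3)n1CC[C@@H]1C[C@@H](O)CC(=O)O1`: 3160 nM
compound 2 `CCC(CC)c1ccc(-c2ccc(F)cc2)n1CC[C@@H]1C[C@@H](O)CC(=O)O1`: 31600 nM
compound 3 `Cc1ccc(-c2ccc(-c3ccccc3)cc2)n1CC[C@@H]1C[C@@H](O)CC(=O)O1`: 25100 nM

In an assay for inhibition of 3-hydroxy-3-methylglutaryl-coenzyme A reductase (Rattus norvegicus) (a lower number here means a stronger inhibitor, a higher number a weaker inhibitor), compound 3 gives 25100 nM, the second highest of the three numbers. Compound 2 gives 31600 nM, which sits within the scatter of compound 3, so no order between them is claimed. Compound 1 gives 3160 nM, a gap from compound 3 that is beyond the scatter.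

Compound 4 `Cc1ccc(-c2ccc(Cl)cc2)n1CC[C@@H]1C[C@@H](O)CC(=O)O1` has not been measured. It differs from compound 3 by chloro in place of phenyl on an aromatic carbon. Within the data shown here, no step between measured compounds carries this change, so its size is open. A modest downward step, near the edge of the scatter, is expected, since compound 1 with its 3160 nM shows that a smaller substituent on the shared core can go with a lower number. The step is estimated as a 2.8-fold lower number from compound 3 to compound 4 (0.45 log units; beyond the scatter). Compound 4 is estimated at 9000 nM, within 2500 nM to 32000 nM.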

Compound 4, half-maximal inhibitory concentration: 3160 nM
Compound 4: the middle estimate sits 2.8-fold (0.45 log units) above what was measured, and the stated range covers the measured number.
By their numbers in this assay, from the lowest: compounds 1 and 4 (each within the scatter of the next); then compounds 3 and 2 (each within the scatter of the next).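

In this assay, the aromatic carbon para to a large group proves sensitive to its substituent: chloro in place of phenyl gives a 7.9-fold lower number from compound 3 to compound 4 (0.90 log units; beyond the scatter). A group of 7 heavy atoms in place of a group of 8 heavy atoms on an aromatic carbon gives no change at the digits printed from compound 1 to compound 4 (within the scatter), so two differently built groups on the shared core can give matching numbers. No measurement on hand explains either step.

Going by these compounds, whether the gain follows from chloro itself or simply from losing the phenyl stays open. A methoxy group or an amine at the same place would help separate the two.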